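A few compounds are considered here, and "the series" means these few. Any claim that something is new, unique, unknown or untested is made for them only; others in the source may bear on it.

- compound 1 `CCCOC(=O)c1sc2cc(Oc3ccnc(C(=O)NC)c3)ccc2c1C` gives 57100 nM in an ADME assay on HeLa cells (Homo sapiens) for cytotoxicity, read by MTT assay, with a stated time of 2 days (a higher number here means that more compound is tolerated, a lower number that less compound is tolerated), as a measured number
- compound 2 `CNC(=O)c1cc(Oc2ccc3c(C)c(C(=O)O)sc3c2)ccn1` gives > 100000 nM as a limit of the assay, not a number

Compound 2 therefore has only a limit and no exact place in the series. Compound 3 `CCNC(=O)c1sc2cc(Oc3ccnc(C(=O)NC)c3)ccc2c1C` carries the change ethylamino in place of hydroxy on a carbonyl carbon with ethylamino in place of hydroxy on a carbonyl carbon. Among the measured compounds shown here, the one measured step that bears on this is an at least 1.7-fold higher number from compound 1 to compound 2 (0.24 log units; that floor lies within the scatter) with hydrogen in place of propyl on an oxygen next to a carbonyl group, and its floor lies within the scatter. A small move to a lower number is expected in this assay since compound 1 gives 57100 nM without the hydroxy, though the move may stay within the scatter. The expected step is an at least 1.4-fold lower number from compound 2 to compound 3 (0.15 log units; that floor lies within the scatter) as an estimate only. Compound 3 is estimated at 70000 nM with an expected range of 30000 nM to 140000 nM for the measurement.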

Compound 3, half-maximal cytotoxic concentration: > 100000 nM
Compound 3: a limit, no number (the forecaster's own chance of this, stated with the estimate: 35%); middle value at least 1.4-fold (0.15 log units) away from the limit.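

In this assay, compound 3 gives > 100000 nM, a limit and not a number. Ethylamino on the carbonyl carbon thus joins hydroxy at that limit, and the change from propoxy reads as an at least 1.7-fold higher number from compound 1 to compound 3 (0.24 log units; that floor lies within the scatter). The step between compound 2 and compound 3 cannot be read, and only compound 1 keeps a number: the limit of > 100000 nM in this assay, at which 2 of the 3 values shown sit.

Still open, as far as these compounds go, is whether a longer alkyl amine on the carbonyl carbon would give a measured number in this assay. Also open, from the compounds shown here alone, is whether any group there would stand beyond the scatter from compound 1.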